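Two ring stereocentres inverted in a cyclic peroxide acid

The source may hold more compounds than are shown below. What is called first, only, known or untested is meant among the compounds shown, and "the series" means these compounds.

Among the measured compounds shown here, in a functional assay on SNB-75 cells (Homo sapiens) for inhibition (a lower number here means a stronger inhibitor of growth, a higher number a weaker inhibitor of growth), compound 2 `C=C1CCCC(C)(C)C1CC[C@@]1(C)CC[C@H]([C@@H](C)C(=O)O)OO1` gives 3390 nM, the only number measured here. Compound 1 `COC(=O)[C@H](C)[C@H]1CC[C@@](C)(CCC2=C(C)CCCC2(C)C)OO1` reaches only a limit of the assay, > 25000 nM. Compound 3 `C=C1CCCC(C)(C)C1CC[C@]1(C)CC[C@@H]([C@@H](C)C(=O)O)OO1` has not yet been measured. It differs from compound 2 in this way: the two compounds have the same atoms and bonds; at least one stereo element is drawn with a configuration in one of them and without one in the other: 2 of 4 stereo elements differ; a stereocentre at a saturated ring carbon is drawn S in compound 2 and R in compound 3; a stereocentre at a saturated ring carbon is drawn R in compound 2 and S in compound 3. For the measured compounds named here, no measured pair here shows what such a change does, so the direction of the step is not known. The expected step from compound 2 to compound 3 is a 1.8-fold higher number from compound 2 to compound 3 (0.25 log units; within the scatter), set toward weaker inhibition with wide uncertainty. Compound 3 is thus estimated to give 6000 nM, between 1500 nM and 25000 nM.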

Compound 3, concentration for 50% growth inhibition: > 10000 nM
Compound 3 was reported as a limit (the forecaster's own chance of this, stated with the estimate: 25%); middle value at least 1.6-fold (0.22 log units) from the limit.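

Among the compounds shown here, this pair gives the first reading of what the arrangement at these two ring stereocentres does, and the direction is now clear: with atoms and bonds unchanged, inverting both gives an at least 2.9-fold higher number from compound 2 to compound 3 (0.46 log units; beyond the scatter) in this assay. From the compounds shown here alone, compound 3 gives > 10000 nM, which is a limit of the assay, so the full size of the step remains unknown.

Going by these compounds, whether one inverted stereocentre alone would produce this loss remains open. So does how an amide in place of the carboxylic acid would behave under either ring arrangement.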